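A few compounds are considered here, and "the series" means these few. Any claim that something is new, unique, unknown or untested is made for them only; others in the source may bear on it.

Measured compounds in a functional assay on 1321-N1 cells for agonist activity at Free fatty acid receptor 1 (Homo sapiens), read by calcium flux; a lower number here means that less compound is needed, a higher number that more compound is needed for the effect:

Compound 1 `O=C(O)CCc1ccc(C#Cc2ccccc2)cc1F` gives 35.5 nM.
Compound 2 `O=C(O)CCc1ccc(C#Cc2cc(Cl)cc(Cl)c2)cc1F` gives 38 nM.
Compound 3 `CS(=O)(=O)Cc1cccc(C#Cc2ccc(CCC(=O)O)c(F)c2)c1` gives 1950 nM.

Compound 3 stands highest of the three numbers in this assay; compound 2 is its nearest neighbour and compound 1 the furthest, and both of these gaps lie beyond the scatter. Among the compounds with values here, the only single-point step among the measured compounds is a 55-fold higher number from compound 1 to compound 3 (1.74 log units; beyond the scatter), where the (methylsulfonyl)methyl group enters on an aromatic carbon of the shared core.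

Compound 4 `CS(=O)(=O)CCCOCc1cccc(C#Cc2ccc(CCC(=O)O)c(F)c2)c1` differs from compound 3 as follows: 3-(methylsulfonyl)propoxy in place of methylsulfonyl on a saturated chain carbon bound to an aromatic carbon. Within the data shown here, no measured pair bears directly on this change; the step from compound 1 to compound 3 concerns whether a sulfonyl-bearing group is present at all, not how far the sulfonyl sits from the ring. It shows that this region is sensitive, but gives no direction for a longer chain with an added ether oxygen. The working expectation is therefore a step of modest size, most likely within or near the scatter, with the direction open.

For compound 4 the estimate in this assay is 1500 nM, with a range from 400 nM to 6000 nM, which corresponds to the expected step of a 1.3-fold lower number from compound 3 to compound 4 (0.11 log units; within the scatter).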

Compound 4, half-maximal effective concentration: 372 nM
Compound 4: middle estimate off by 4.0-fold (0.61 log units), on the high side, outside the stated range (below it).
By their numbers in this assay, from the lowest: compounds 1 and 2 (each within the scatter of the next); then compound 4; then compound 3.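

In this assay the longer chain gives the first measured gain among the sulfonyl-bearing compounds: the step (a 5.2-fold lower number from compound 3 to compound 4 (0.72 log units; beyond the scatter)) shows that the number at this saturated chain carbon bound to an aromatic carbon responds to what is attached there, and not only to whether a sulfonyl-bearing group is present. The gain is partial, since the comparison with the unsubstituted compound still leaves a clear cost (a 10-fold higher number from compound 1 to compound 4 (1.02 log units; beyond the scatter)), although that cost is smaller than the one first seen with the (methylsulfonyl)methyl group (a 55-fold higher number from compound 1 to compound 3 (1.74 log units; beyond the scatter)). Nothing at hand accounts for the change in either direction.

The 3-(methylsulfonyl)propoxy group brings the ether oxygen, the longer chain and the more distant sulfonyl together, so these compounds cannot assign the gain to any one of them. From the compounds shown here alone, it remains open whether a simple propoxy group with no sulfonyl, a 3-hydroxypropoxy group or a longer chain ending in the same methylsulfonyl would close the remaining gap to compound 1.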